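The compounds below may be only part of what the source reports. "The series", "measured", "known", "first", "only" and "open" are said of these compounds alone.

In a functional assay on NCI-H1299 cells (Homo sapiens) for antiproliferative activity, read by CCK-8 assay, with a stated time of 72 h (on this read-out lower numbers stand for stronger inhibition and higher numbers for weaker inhibition), compound 1 `Nc1ccccc1NC(=O)c1ccc(CSC(=S)N2CCN(c3ccccc3)CC2)cc1` gives 610 nM and compound 2 `Nc1ccccc1NC(=O)c1ccc(CSC(=S)N2CCN(c3ccc(F)cc3)CC2)cc1` gives 980 nM. Compound 3 `Nc1ccccc1NC(=O)c1ccc(CSC(=S)N2CCc3cc(Cl)ccc32)cc1` gives 3280 nM, the highest of the three numbers and beyond the scatter from both others. Compound 4 `CCN(Cc1ccncc1)C(=S)SCc1ccc(C(=O)Nc2ccccc2N)cc1` carries ethyl((pyridin-4-yl)methyl)amino in place of 5-chloro-2,3-dihydro-1H-indol-1-yl on a thiocarbonyl carbon. Among the measured compounds shown here, the only measured single change is fluoro in place of hydrogen, a 1.6-fold higher number from compound 1 to compound 2 (0.21 log units; within the scatter). For the measured compounds named here, that is a different change from this one, so it offers only a weak guide, and no measured pair tests this swap. No step beyond the scatter is therefore expected in this assay. The estimated step is a 1.6-fold lower number from compound 3 to compound 4 (0.21 log units; within the scatter). For compound 4 the expected value is 2000 nM, with an estimated range of 500 nM to 7000 nM.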

Compound 4, half-maximal inhibitory concentration: 750 nM
Beside the measured number, compound 4's estimate is 2.7-fold (0.43 log units) above it; the range from low to high includes it.
By their numbers in this assay, from the lowest: compounds 1, 4 and 2 (each within the scatter of the next); then compound 3.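

In this assay, among the compounds shown here, the group on the thiocarbonyl carbon gives the first step beyond the scatter, a 4.4-fold lower number from compound 3 to compound 4 (0.64 log units; beyond the scatter). The earlier fluoro step stayed within the scatter, so this position is the first shown to move the number. Both groups have the same heavy-atom count, so that count does not separate them, but the swap changes the chlorine, the ring type and the ring nitrogen together. An ethyl(benzyl)amino group, lacking only the pyridine nitrogen, would help separate these changes. Nothing measured here explains the step.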